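Thiosemicarbazone series: ring size and pyridine methyl

The source may report more compounds than this note shows. Statements on the series, on what has been measured and on what is new or still open speak of the compounds shown alone.

Measured compounds:
compound 1, `N/C(=N\NC(=S)N1CCCCCC1)c1ccccn1`, 90%
compound 2, `Cc1cccc(/C(N)=N/NC(=S)N2CCCCCC2)n1`, 70.3%
compound 3, `Cc1cccc(/C(N)=N/NC(=S)N2CCCC2)n1`, 60.8%

The read-out throughout is a functional assay on A-375 cells (Homo sapiens) for cytotoxicity, read by MTT assay, with a stated time of 72 h, tested at 30 uM; on this read-out higher numbers stand for more inhibition of growth at the one concentration tested and lower numbers for less inhibition of growth. Compound 1 gives 90%, compound 2 gives 70.3% and compound 3 gives 60.8% in this assay. Among the measured compounds shown here, compound 2 and compound 3 lie within the scatter of each other; compound 3 and compound 1 are separated by more than the scatter, but no single-point step links them. The difference between the core of compound 2 and the core of compound 3 is not broken down here.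

One change is seen once in a measured pair: hydrogen in place of methyl on an aromatic carbon. It brings a number 19.7 percentage points higher from compound 2 to compound 1 (beyond the scatter), a modest gain but beyond the scatter.

Compound 4, `N/C(=N\NC(=S)N1CCCC1)c1ccccn1`, has not yet been run. It differs from compound 3 by hydrogen in place of methyl on an aromatic carbon, the same change as between compound 2 and compound 1, at the same place on the ring. The expectation for compound 4 rests on that single precedent: the step from compound 3 to compound 4 is estimated as a number 18.2 percentage points higher from compound 3 to compound 4 (beyond the scatter), about the size seen from compound 2 to compound 1, because that pair gave a number 19.7 percentage points higher from compound 2 to compound 1 (beyond the scatter). Compound 4 is therefore expected to reach 79% in this assay, with a plausible range from 65% to 92%. For the measured compounds named here, with only one example of the change, the width of that range is deliberate.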

Compound 4, percent growth inhibition at one concentration: 86%
Compound 4: middle estimate off by 7 percentage points, on the low side, and the stated range covers the measured number.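

In this assay, hydrogen in place of methyl on an aromatic carbon next to the ring nitrogen gives a number 25.2 percentage points higher from compound 3 to compound 4 (beyond the scatter), so the change now has a second example on a second core. The two examples point the same way and do not differ in size beyond the scatter: the same change on two cores in this assay, a number 19.7 percentage points higher (beyond the scatter) from compound 2 to compound 1 and a number 25.2 percentage points higher (beyond the scatter) from compound 3 to compound 4, 5.5 percentage points apart, within the scatter of two such steps

These two pairs show that the gain carried over between these two cores, at this one place and at the single concentration tested. They do not show that it would hold on any other core, they give no concentration-response information, and they offer no explanation for the gain.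

Only methyl and hydrogen are shown at this place, so a methoxy group, a chlorine atom, an amine or a longer chain such as ethyl remains open there. Also open, from the compounds shown here alone, is whether an open-chain dialkylamine in place of the saturated ring would keep the inhibition of growth, and whether the methyl-to-hydrogen step would then stay the same.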